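A few compounds are considered here, and "the series" means these few. Any claim that something is new, unique, unknown or untested is made for them only; others in the source may bear on it.

Series in a functional assay on KB cells (Homo sapiens) for antiproliferative activity, read by sulforhodamine B assay, with a stated time of 3 days; a lower number here means that less compound is needed, a higher number that more compound is needed for the effect:
- compound 1 `CCC1=C(O)c2c(oc(-c3cccc(OC)c3)cc2=O)C(CC)(CC)C1=O`: 13.3 uM
- compound 2 `CCC1=C(O)c2c(oc(-c3ccccc3OC)cc2=O)C(CC)(CC)C1=O`: 40.8 uM
- compound 3 `CCC1=C(O)c2c(oc(-c3ccc(OC)c(F)c3)cc2=O)C(CC)(CC)C1=O`: 26.7 uM

Compound 3 is not separated from either neighbour: a 1.5-fold lower number from compound 2 to compound 3 (0.18 log units; within the scatter) and a 2.0-fold higher number from compound 1 to compound 3 (0.30 log units; within the scatter). Next is compound 4 `CCC1=C(O)c2c(oc(-c3cccc(C)c3C)cc2=O)C(CC)(CC)C1=O`, with 2,3-dimethylphenyl in place of 3-fluoro-4-methoxyphenyl on an aromatic carbon, next to the ring oxygen (2,3-dimethylphenyl in place of 3-fluoro-4-methoxyphenyl on an aromatic carbon). The three measured steps are swaps of the aryl group at this same place. Only one exceeds the scatter, and it is modest: a 3.1-fold higher number from compound 1 to compound 2 (0.49 log units; beyond the scatter). Among the measured compounds shown here, no measured compound carries 2,3-dimethylphenyl, so no direction can be assigned, and no step beyond the scatter is expected in this assay. The expected step is a 1.1-fold lower number from compound 3 to compound 4 (0.05 log units; within the scatter). For compound 4 the estimated value is 24 uM, with an expected range of 9 uM to 60 uM.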

Compound 4, concentration for half-maximal effect: 3.1 uM
The estimate for compound 4 lay 7.7-fold (0.89 log units) above the measured number; the whole stated range lies above it.
By their numbers in this assay, from the lowest: compound 4; then compounds 1, 3 and 2 (each within the scatter of the next, the first and the last beyond it).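

In this assay, among the compounds shown here, the aryl group on the aromatic carbon next to the ring oxygen now gives steps larger than any among the earlier compounds: an 8.6-fold lower number from compound 3 to compound 4 (0.94 log units; beyond the scatter), a 13-fold lower number from compound 2 to compound 4 (1.12 log units; beyond the scatter) and a 4.3-fold lower number from compound 1 to compound 4 (0.63 log units; beyond the scatter). For the compounds shown here, the only aryl group here with no oxygen or fluorine, 2,3-dimethylphenyl, gives the lowest number of the series, so the position can respond more strongly than the methoxyphenyl swaps suggested. Nothing available explains this step.

The compounds shown do not separate the contributions of the two methyl groups. From the compounds shown here alone, whether unsubstituted phenyl, phenyl with a single methyl, or phenyl with two chlorines would give a similar number remains open.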